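The source may report more compounds than this note shows. Statements on the series, on what has been measured and on what is new or still open speak of the compounds shown alone.

Four compounds share one core: compound 1 `ClCc1ccccc1Cn1cnc2c(Cl)nc(Cl)nc21`, compound 2 `ClCc1cccc(Cn2cnc3ncnc(Cl)c32)c1`, compound 3 `ClCc1ccc(Cn2cnc3c(Cl)nc(Cl)nc32)cc1` and compound 4 `ClCc1cccc(Cn2cnc3nc(Cl)nc(Cl)c32)c1`. Only one of them carries a result in a functional assay on RPMI-8226 cells (Homo sapiens) for cytotoxicity, read by sulforhodamine B assay, with a stated time of 48 h; on this read-out higher numbers stand for lower toxicity in this test and lower numbers for higher toxicity in this test: compound 2 gives 89100 nM, while compound 1 gives "not determined" (no result reported) and compound 3 gives "not determined" (no result reported), and compound 4 has not yet been tested. Compound 2 therefore stands alone on the numbers shown, with no neighbour to compare against. Compound 4 differs from compound 2 by chloro in place of hydrogen on an aromatic carbon. Within the data shown here, with no measured pair of this kind to lean on, the expected step from compound 2 to compound 4 is a modest gain in toxicity in this assay, about a 1.8-fold lower number from compound 2 to compound 4 (0.25 log units; within the scatter), though a result within the scatter would not surprise. Compound 4 is estimated at 50000 nM, between 15000 nM and 200000 nM.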

Compound 4, concentration lethal to 50% of the cells: > 100000 nM
Compound 4: a limit, no number (the forecaster's own chance of this, stated with the estimate: 25%); middle value at least 2.0-fold (0.30 log units) from the limit.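

In this assay compound 4 gives a limit of the assay and not a number: the limit of > 100000 nM in this assay, at which 1 of the 4 values shown sits. Chloro in place of hydrogen on this aromatic carbon, between two ring nitrogen atoms, gives an at least 1.1-fold higher number from compound 2 to compound 4 (0.05 log units; that floor lies within the scatter), so the change brings no lower number in this test. From the compounds shown here alone, how far the true value of compound 4 lies past its limit remains unknown, and this floor alone cannot separate the two compounds. The compounds shown leave open what an amine or a methoxy group on that same carbon would give in this assay.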